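Removal of the hydroxy from the sugar side chain of compound 3

The source may report more compounds than this note shows. Statements on the series, on what has been measured and on what is new or still open speak of the compounds shown alone.

The series shares one core, a sugar bearing an amino-purine and a glycyl-linked fatty acyl chain, and is read in a functional assay on L1210 cells (Mus musculus) for inhibition, read by thymidine incorporation, with a stated time of 3 h; on this read-out higher numbers stand for an effect only at larger amounts of compound and lower numbers for an effect already at smaller amounts. Compound 1 `CC(C)CCCCCCCCCCCCC(=O)NCC(=O)N[C@@H]1[C@@H](O)[C@H](O)[C@@H](Nc2ncnc3[nH]cnc23)O[C@H]1C` gives 1.8 uM in this assay. Compound 2 `CCOCCC(=O)NCC(=O)N[C@@H]1[C@@H](O)[C@H](O)[C@@H](Nc2ncnc3[nH]cnc23)O[C@H]1C` returns only a limit, > 1000 uM, in this assay; the limit of > 1000 uM in this assay, at which 1 of the 3 values shown sits, marks where that limit sits. Compound 3 `CCCCCCCCCCCC(=O)NCC(=O)N[C@@H]1[C@@H](O)[C@H](O)[C@@H](Nc2ncnc3[nH]cnc23)O[C@H]1CO` gives 20 uM in this assay, which is the highest of the two numbers shown, compound 1 standing beyond the scatter at the lower number.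

Compound 4 `CCCCCCCCCCCC(=O)NCC(=O)N[C@@H]1[C@@H](O)[C@H](O)[C@@H](Nc2ncnc3[nH]cnc23)O[C@H]1C` has not yet been measured in this assay. It is compound 3 with hydrogen in place of hydroxy on a saturated chain carbon bound to a saturated ring carbon. For the measured compounds named here, no measured pair differs in this one place, so the size of the step has to be estimated from the remaining compounds. Compound 1 carries the same hydrogen at this position, together with a longer branched chain, and gives 1.8 uM in this assay, which points towards a lower number for compound 4 than for compound 3. The step from compound 3 to compound 4 is expected to be a 4.0-fold lower number from compound 3 to compound 4 (0.60 log units; beyond the scatter) in this assay, towards a smaller amount of compound. For compound 4 a value of 5 uM is estimated in this assay, within a range of 1.5 uM to 20 uM.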

Compound 4, concentration for half-maximal effect: 29 uM
Compound 4: middle estimate off by 5.8-fold (0.76 log units), on the low side; measured number above the stated range.
By their numbers in this assay, from the lowest: compound 1; then compounds 3 and 4 (each within the scatter of the next). At a limit, above all of these: compound 2.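

Replacing hydroxymethyl with methyl, on a saturated chain carbon bound to a saturated ring carbon, gives a 1.5-fold higher number from compound 3 to compound 4 (0.16 log units; within the scatter) and so leaves no readable effect at this position when the acyl chain stays the same. The large step lies in the chain instead: a 16-fold higher number from compound 1 to compound 4 (1.21 log units; beyond the scatter) accompanies hydrogen in place of isobutyl on a saturated chain carbon. Compound 2 stands at a limit of the assay, so an at least 34-fold lower number from compound 2 to compound 4 (1.53 log units; beyond the scatter) is a bound only, and it goes with nonyl in place of ethoxy on a saturated chain carbon, two bonds along the chain from a carbonyl carbon.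

Nothing shown gives a reason for any of these steps. Still open, from the compounds shown here alone, is whether an amine or a carboxylic acid at this position would also leave the number within the scatter, and whether hydroxymethyl and methyl would remain level on a longer chain such as that of compound 1.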